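Drawn Geometry Alone: From Compound 2 to Compound 4

This account rests on a few compounds, and the source may have more. Where it says the series, first, only, none or still open, it means among the compounds named here.

Measured compounds:
compound 1, `CC(=NNC(=S)Nc1ccc(Cl)cc1)c1ccccn1`, 5.9 nM
compound 2, `CC(=NNC(=S)Nc1ccccc1)c1ccccn1`, 6.8 nM
compound 3, `CC(=NNC(=S)Nc1ccc(F)cc1)c1ccccn1`, 17 nM

In a functional assay on T98G cells (Homo sapiens) for cytotoxicity, read by MTT assay, with a stated time of 48 h (on this read-out lower numbers stand for stronger inhibition and higher numbers for weaker inhibition), compound 2 gives 6.8 nM, the second highest of the three numbers. Its nearest neighbour is compound 1, with a 1.2-fold higher number from compound 1 to compound 2 (0.06 log units; within the scatter). Its furthest is compound 3, with a 2.5-fold higher number from compound 2 to compound 3 (0.40 log units; beyond the scatter); the other measured step is a 2.9-fold higher number from compound 1 to compound 3 (0.46 log units; beyond the scatter).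

Compound 4, `C/C(=N/NC(=S)Nc1ccccc1)c1ccccn1`, is the unmeasured compound. Compared with compound 2 the difference is the two compounds have the same atoms and bonds; at least one stereo element is drawn with a configuration in one of them and without one in the other: 1 of 1 stereo elements differ; a double bond is drawn without a configuration in compound 2 and Z in compound 4.

Among the compounds with values here, none of the measured steps touches a stereo element; each of them swaps a substituent on an aromatic carbon, so no step bears directly on this change. With the same atoms and bonds and only a drawn double-bond configuration differing, the expectation is no step beyond the scatter in this assay. Compound 4 is therefore estimated at 6.8 nM, with a range from 3.4 nM to 14 nM. The expected step is no change at the digits printed from compound 2 to compound 4 (within the scatter).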

Compound 4, half-maximal inhibitory concentration: 6.81 nM
Beside the measured number, compound 4's estimate is 1.0-fold (0.00 log units) below it; measured number inside the range.
By their numbers in this assay, from the lowest: compounds 1, 2 and 4 (each within the scatter of the next); then compound 3.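

The earlier compounds shown here varied only a substituent on an aromatic carbon, whereas here the double bond is the place of change, and in this assay the result is a 1.0-fold higher number from compound 2 to compound 4 (0.00 log units; within the scatter). Between these two compounds, a double bond drawn as Z therefore goes with no change beyond the scatter. Within the data shown here, this is not a comparison of two defined geometries, because only one compound has a configuration drawn at that double bond: the fact that one of compounds 2 and 4 is drawn with a defined configuration and the other without, at the place where they differ.

The compounds shown leave open whether a double bond drawn as E would give a similar number, and whether chloro and fluoro would give the same steps with the Z configuration drawn. As far as these compounds go, how an amine or a methoxy group on the same aromatic carbon would read in this assay also remains open.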